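A few compounds are considered here, and "the series" means these few. Any claim that something is new, unique, unknown or untested is made for them only; others in the source may bear on it.

In a functional assay on GBM2 cells (Homo sapiens) for antiproliferative activity, read by WST assay, with a stated time of 72 h (a lower number here means a stronger inhibitor, a higher number a weaker inhibitor), compound 1 `O=C(Nc1cccc(Cl)c1)Nc1cc2ncncc2cc1OCc1cccc(Cl)c1` gives 3500 nM, compound 2 `O=C(Nc1ccc(C(F)(F)F)cc1)Nc1cc2ncncc2cc1OCc1cccc(Cl)c1` gives 4700 nM, and compound 3 `O=C(Nc1ccc(C(F)(F)F)cc1)Nc1cc2ncncc2cc1OCc1ccccc1` gives 8600 nM. Compound 4 `O=C(Nc1cccc(Cl)c1)Nc1cc2ncncc2cc1OCc1ccccc1` has not yet been tested in this assay. The change from compound 3 to compound 4 is 3-chlorophenyl in place of 4-(trifluoromethyl)phenyl on an amide-type nitrogen. The same change is seen once already, from compound 2 to compound 1, where it is 3-chlorophenyl in place of 4-(trifluoromethyl)phenyl on an amide-type nitrogen and gives a 1.3-fold lower number from compound 2 to compound 1 (0.13 log units; within the scatter). The two cores differ in that compound 3 carries hydrogen in place of chloro on an aromatic carbon relative to compound 2, a step that reads a 1.8-fold higher number from compound 2 to compound 3 (0.26 log units; within the scatter). Since the place of the change is the same in both pairs, compound 4 is expected to move from compound 3 by about a 1.3-fold lower number from compound 3 to compound 4 (0.12 log units; within the scatter), resting on the step from compound 2 to compound 1. Compound 4 is therefore estimated at 6500 nM, most likely between 3000 nM and 13000 nM.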

Compound 4, half-maximal inhibitory concentration: 4100 nM
Beside the measured number, compound 4's estimate is 1.6-fold (0.20 log units) above it; low and high end bracket the measured number.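

In this assay the step to 3-chlorophenyl in place of 4-(trifluoromethyl)phenyl on an amide-type nitrogen reads a 2.1-fold lower number from compound 3 to compound 4 (0.32 log units; beyond the scatter) and agrees with its counterpart on the other core: the same change on two cores in this assay, a 1.3-fold lower number (0.13 log units; within the scatter) from compound 2 to compound 1 and a 2.1-fold lower number (0.32 log units; beyond the scatter) from compound 3 to compound 4, 1.6-fold (0.19 log units) apart, within the scatter of two such steps. The step to hydrogen in place of chloro on an aromatic carbon reads a 1.2-fold higher number from compound 1 to compound 4 (0.07 log units; within the scatter) and likewise agrees with its counterpart: the same change on two cores in this assay, a 1.8-fold higher number (0.26 log units; within the scatter) from compound 2 to compound 3 and a 1.2-fold higher number (0.07 log units; within the scatter) from compound 1 to compound 4, 1.6-fold (0.19 log units) apart, within the scatter of two such steps. Each change therefore carried across these two cores within the scatter, but two pairs per change do not show that it would carry to any other core in the series.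

Going by these compounds, whether either step holds with an amine or a carboxylic acid in place of the chloro, or with a longer chain in place of the 3-chlorophenyl, stays open.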